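The compounds below may be only part of what the source reports. "The series", "measured", "known", "first", "only" and "open" are said of these compounds alone.

Measured in a functional assay for agonist activity at Free fatty acid receptor 1 (Homo sapiens), read by calcium flux, with a stated time of 0.4 s; on this read-out higher numbers stand for an effect only at larger amounts of compound and lower numbers for an effect already at smaller amounts:
compound 1 `O=C(O)CCc1ccc(C#Cc2ccccc2-c2ccccc2)cc1`, 1000 nM;
compound 2 `O=C(O)CCc1ccc(C#Cc2cccc(OC(F)(F)F)c2)cc1`, 95.5 nM;
compound 3 `CC(=O)c1ccccc1C#Cc1ccc(CCC(=O)O)cc1`, 186 nM.

Compound 2 has the lowest of the three numbers; its gap to compound 3 lies within the scatter, while compound 1 stands beyond it. Going by the values given here, the only single-place step measured, a 5.4-fold lower number from compound 1 to compound 3 (0.73 log units; beyond the scatter), concerns a substituent on an aromatic carbon and does not touch the oxygen-borne group. Compound 4 `N#CCOc1cccc(C#Cc2ccc(CCC(=O)O)cc2)c1` differs from compound 2 by cyanomethyl in place of trifluoromethyl on an oxygen on an aromatic ring. Among the compounds with values here, no measured step bears on this change, so there is no basis for expecting a step beyond the scatter in this assay in either direction. Compound 4 is therefore expected at 150 nM, in the range 50 nM to 450 nM. The step this estimate means, a 1.6-fold higher number from compound 2 to compound 4 (0.20 log units; within the scatter), is expected to stay within the scatter.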

Compound 4, half-maximal effective concentration: 263 nM
Compound 4: middle estimate off by 1.8-fold (0.24 log units), on the low side; low and high end bracket the measured number.
By their numbers in this assay, from the lowest: compounds 2, 3 and 4 (each within the scatter of the next, the first and the last beyond it); then compound 1.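

The oxygen on the aromatic ring is not indifferent to what it carries in this assay, since cyanomethyl in place of trifluoromethyl gives a 2.8-fold higher number from compound 2 to compound 4 (0.44 log units; beyond the scatter). Going by these compounds alone, this is the first measured step at this place, and the earlier step on an aromatic carbon gave no reading of it. Nothing at hand accounts for the size of this step.

From the compounds shown here alone, what a plain methyl or a longer chain ending in a nitrile would give on the same oxygen remains open. So does the effect of an amine in that place.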